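A few compounds are considered here, and "the series" means these few. Any claim that something is new, unique, unknown or untested is made for them only; others in the source may bear on it.

Of the compounds shown here, three have been tested in an ADME assay on HEK-293T cells (Homo sapiens) for cytotoxicity, read by CCK-8 assay, with a stated time of 48 h; a lower number here means a stronger inhibitor, a higher number a weaker inhibitor. Compound 1, `COc1ccc(Oc2ccccc2-c2ccsc2S(=O)(=O)N2CCN(C(=S)Nc3ccc([N+](=O)[O-])cc3)CC2)cc1OC`, gives > 20000 nM, which is a limit of the assay and not a number. Compound 3, `Cc1cc(C)cc(NC(=O)NCCNS(=O)(=O)c2ccc(-c3ccccc3Oc3ccc([N+](=O)[O-])c([N+](=O)[O-])c3)s2)c1`, gives > 50000 nM, which is also a limit. Compound 2, `O=C(NCCNS(=O)(=O)c1sccc1-c1ccccc1Oc1ccc(O)c(O)c1)Nc1cc(Cl)cc(Cl)c1`, is the only one of the three with a measured number, at 10700 nM. Compound 1 therefore stands at a limit, and it is one of two compounds that do so.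

Compound 4, `COc1ccc(Oc2ccccc2-c2ccsc2S(=O)(=O)N2CCN(C(=S)Nc3ccc(Cl)cc3)CC2)cc1OC`, keeps the core of compound 1 and differs from it in one place: chloro in place of nitro on an aromatic carbon. This is chloro in place of nitro on an aromatic carbon, para to a large group, so that 4-nitrophenyl becomes 4-chlorophenyl. For the measured compounds named here, no measured pair in this set shows what such a change does in this assay, so the expectation is cautious. The estimated change, a step that the limit leaves unreadable from compound 1 to compound 4, is expected to stay within the usual scatter and to have no clear direction. Going by the values given here, the only measured number, that of compound 2 at 10700 nM, guides the expected low end of the range. For compound 4 the estimated value is 22000 nM, with an expected range from 9000 nM to 50000 nM.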

Compound 4, half-maximal inhibitory concentration: > 20000 nM
Compound 4 was reported as a limit; the forecaster's own chance of this, stated with the estimate: 50%; the middle value is on the limit's open side.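

In this assay compound 4 gives > 20000 nM, which is a limit of the assay and not a number. Compound 1 also stands at a limit, so no step can be read between compound 1 and compound 4. The compounds shown leave open how far chloro in place of nitro shifts the value in this assay.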